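This account rests on a few compounds, and the source may have more. Where it says the series, first, only, none or still open, it means among the compounds named here.

Working notes on the series. In an assay on HEK293 cells for positive allosteric modulation of metabotropic glutamate receptor 2 (Rattus norvegicus), read by thallium flux, with a stated time of 2.5 min (on this read-out lower numbers stand for smaller maximal responses and higher numbers for larger maximal responses), compound 3 `Cc1c(OCCCCOc2ccc(F)c(C(=O)O)c2)ccc(C(=O)CC(C)(C)C)c1O` gives 94.6%, the highest of the three numbers measured. Its nearest neighbour is compound 2 `CCCC(=O)c1ccc(OCCCCOc2ccc(F)c(C(=O)O)c2)c(C)c1O`, which in this assay gives 87.5%; the step of a number 7.1 percentage points higher from compound 2 to compound 3 (within the scatter) is within the scatter. Furthest off is compound 1 `Cc1cc(C(=O)O)ccc1OCCCCOc1ccc(C(=O)CC(C)C)c(O)c1C`, which in this assay gives 83.9%, a number beyond the scatter below compound 3; compound 1 differs from compound 3 in more than one place, so only the two values themselves can be compared.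

Compound 4 `Cc1c(OCCCCOc2ccc(C(=O)CC(C)(C)C)c(O)c2C)cccc1C(=O)O` is not yet measured. It differs from compound 3 in one place: 3-carboxy-2-methylphenyl in place of 3-carboxy-4-fluorophenyl on an oxygen on a saturated carbon. Going by the values given here, no measured step touches this part of the molecule: the single step on record, from compound 2 to compound 3, concerns the saturated chain carbon bound to the carbonyl carbon, not the aryl group on the oxygen. The step from compound 2 to compound 3 is small, and the spread of all three maximal responses is narrow. Compound 4 is therefore expected to sit close to compound 3, with the step of a number 5.6 percentage points lower from compound 3 to compound 4 (within the scatter) expected not to exceed the scatter. The estimate for compound 4 in this assay is 89%, with a range from 76% to 101%.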

Compound 4, largest response reached (reported as percent of maximum), in percent of the reference or control that the assay uses: 95.8%
Compound 4: the middle estimate sits 6.8 percentage points below what was measured, within the range that was stated.
By their numbers in this assay, from the lowest: compounds 1, 2, 3 and 4 (each within the scatter of the next, the first and the last beyond it).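

In this assay, going by these compounds alone, the aryl group on the oxygen on a saturated carbon now has a step of its own, a number 1.2 percentage points higher from compound 3 to compound 4 (within the scatter), which the single earlier step, at the saturated chain carbon bound to the carbonyl carbon, could not show. At this level of the read-out, then, 3-carboxy-2-methylphenyl and 3-carboxy-4-fluorophenyl cannot be told apart on this core, so the fluorine can give way to a methyl on the ring that holds the carboxylic acid without a change that exceeds the usual scatter, a statement that holds for this one pair only. Nothing available bears on why the two groups read alike.

All the compounds shown carry a carboxylic acid on this aryl group, so they leave open how a primary amide or a tetrazole would read in its place. They also say nothing on whether a longer chain in place of the saturated chain that carries this oxygen would keep the maximal response, or on how a different group on the ring, such as methoxy or chlorine, would compare with the fluorine and the methyl.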